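From phenyl to methoxy: compound 1 and compound 4

The source may hold more compounds than are shown below. What is called first, only, known or untested is meant among the compounds shown, and "the series" means these compounds.

Measured in a toxicity assay on GES1 cells (Homo sapiens) for inhibition, read by MTT assay, with a stated time of 72 h; on this read-out lower numbers stand for stronger inhibition and higher numbers for weaker inhibition:
Compound 1 `O=C(NCc1ccc(NC(=O)c2cc(-c3ccccc3)ccc2N2CCCC2)cc1)OCc1cccnc1`: > 100000 nM
Compound 2 `O=C(NCc1ccc(NC(=O)c2cccc(F)c2N2CCCC2)cc1)OCc1cccnc1`: > 100000 nM
Compound 3 `O=C(NCc1ccc(NC(=O)c2ccc(F)cc2N2CCCC2)cc1)OCc1cccnc1`: > 100000 nM

Compound 1 stands at > 100000 nM, which is a limit of the assay and not a number. Within the data shown here, the series offers only (the limit of > 100000 nM in this assay, at which 3 of the 3 values shown sit), so no measured step is available as a guide. Compound 4 `COc1ccc(N2CCCC2)c(C(=O)Nc2ccc(CNC(=O)OCc3cccnc3)cc2)c1` has not yet been measured. It differs from compound 1 by methoxy in place of phenyl on an aromatic carbon, para to a pyrrolidin-1-yl group. Resting on (the limit of > 100000 nM in this assay, at which 3 of the 3 values shown sit), no step beyond the scatter is expected in this assay, in either direction. The expected change is a number no higher from compound 1 to compound 4 (the limit leaves the size open), an estimate only. The value expected for compound 4 is 100000 nM, with an estimated range from 40000 nM to 250000 nM, and the assay may well report only a limit again.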

Compound 4, half-maximal inhibitory concentration: > 100000 nM
Compound 4: no number, only a limit (the forecaster's own chance of this, stated with the estimate: 85%); the middle value sits exactly at the limit.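

Among these compounds, compound 1 and compound 4 both give only a limit in this assay, so no step between them can be read: the limit of > 100000 nM in this assay, at which 4 of the 4 values shown sit. The compounds shown leave open how far any of them actually inhibits in this assay, and whether phenyl and methoxy differ at all.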